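This account rests on a few compounds, and the source may have more. Where it says the series, first, only, none or still open, it means among the compounds named here.

In these notes on the series, a functional assay on NCI-H1993 cells (Homo sapiens) for inhibition, read by CCK-8 assay, with a stated time of 72 h (on this read-out higher numbers stand for weaker inhibition and lower numbers for stronger inhibition), is the read-out for all compounds. In this assay, compound 1 `Oc1nc2ncc(-c3ccccc3)nc2n1Cc1ccc2ncccc2c1` gives > 10000 nM, which is a limit of the assay and not a number. Compound 2 `Cn1nccc1-c1cnc2ncn(Cc3ccc4ncccc4c3)c2n1` reads 7910 nM, and compound 3 `c1cnc2ccc(Cn3cnc4ncc(-c5cn[nH]c5)nc43)cc2c1` reads 2890 nM. Compound 3 therefore holds the lower of the two actual numbers.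

The next structure, compound 4 `OCCn1cc(-c2cnc3ncn(Cc4ccc5ncccc5c4)c3n2)cn1`, carries 2-hydroxyethyl in place of hydrogen on an aromatic nitrogen of compound 3: 2-hydroxyethyl in place of hydrogen on an aromatic nitrogen. Going by the values given here, only one measured step touches this ring: a 2.7-fold lower number from compound 2 to compound 3 (0.44 log units; beyond the scatter), with 1H-pyrazol-4-yl in place of 1-methyl-1H-pyrazol-5-yl on an aromatic carbon. That step is modest, and it changes the whole group rather than isolating a substituent on the nitrogen. Among the compounds with values here, no measured pair shows the effect of adding a group at this nitrogen of 1H-pyrazol-4-yl, so the direction remains open and the range must stay wide. In this assay, the expected change is small and not clearly beyond the scatter, estimated as a 1.3-fold lower number from compound 3 to compound 4 (0.12 log units; within the scatter). For compound 4 the estimated value is 2200 nM, with an expected range of 500 nM to 8000 nM.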

Compound 4, half-maximal inhibitory concentration: 2330 nM
For compound 4 the middle estimate is 1.1-fold (0.02 log units) below the measured one; the range from low to high includes it.
By their numbers in this assay, from the lowest: compounds 4 and 3 (each within the scatter of the next); then compound 2. At a limit, above all of these: compound 1.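

In this assay, the first substituent read at this aromatic nitrogen gives a 1.2-fold lower number from compound 3 to compound 4 (0.09 log units; within the scatter) and so leaves hydrogen and 2-hydroxyethyl indistinguishable, which means that this position accepts the chain without a loss beyond the scatter. Set against 1-methyl-1H-pyrazol-5-yl, the new group gives a 3.4-fold lower number from compound 2 to compound 4 (0.53 log units; beyond the scatter) as a modest step, and it runs in the same direction as a 2.7-fold lower number from compound 2 to compound 3 (0.44 log units; beyond the scatter) so that the 1H-pyrazol-4-yl attachment reads lower than that group with or without the chain on its nitrogen. No measured property at hand bears on this result.

As far as these compounds go, whether an amine, a carboxylic acid or a longer chain at this nitrogen would move the number beyond the scatter stays open, and so does the effect of a simple methyl there, which would show whether the hydroxyl of the chain matters at all. With only hydrogen and 2-hydroxyethyl shown at this position, the two readings fix no trend in either direction.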